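This account rests on a few compounds, and the source may have more. Where it says the series, first, only, none or still open, it means among the compounds named here.

Measured compounds in a functional assay on HCT-116 cells (Homo sapiens) for inhibition; on this read-out higher numbers stand for weaker inhibition and lower numbers for stronger inhibition:

compound 1, `CCNC(=O)c1noc(-c2cc(C(C)C)c(O)cc2O)c1-c1cc(COCC(=O)O)no1`: "not determined" (no result reported)
compound 2, `CCNC(=O)c1noc(-c2cc(C(C)C)c(O)cc2O)c1-c1cc(CNC(C)=O)no1`: 167 nM
compound 3, `CCNC(=O)c1noc(-c2cc(C(C)C)c(O)cc2O)c1-c1cc(CN(CC)CC)no1`: 38 nM

Compound 2 stands highest of the two numbers available in this assay; its nearest neighbour is compound 3, and the step is a 4.4-fold lower number from compound 2 to compound 3 (0.64 log units; beyond the scatter). Compound 1 contributes no number.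

Compound 4, `CCNC(=O)c1noc(-c2cc(C(C)C)c(O)cc2O)c1-c1ccn(C(C)C)n1`, differs from compound 2 in one place: 1-isopropyl-1H-pyrazol-3-yl in place of 3-(acetamidomethyl)-1,2-oxazol-5-yl on an aromatic carbon. Within the data shown here, the only measured step, a 4.4-fold lower number from compound 2 to compound 3 (0.64 log units; beyond the scatter), exchanges the group on the 1,2-oxazol-5-yl ring while keeping that ring, whereas compound 4 exchanges the whole ring for 1-isopropyl-1H-pyrazol-3-yl. That step therefore bears on the change only loosely. Among the measured compounds shown here, since compound 2 gives the highest number and its one neighbour with the acetamido group removed gives a 4.4-fold lower number from compound 2 to compound 3 (0.64 log units; beyond the scatter), a step toward lower numbers beyond the scatter is expected for compound 4, but of modest size and with wide uncertainty; the expected step is a 1.9-fold lower number from compound 2 to compound 4 (0.27 log units; within the scatter). In this assay compound 4 is estimated at 90 nM, expected within 25 nM to 350 nM.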

Compound 4, half-maximal inhibitory concentration: 19 nM
Estimate against measurement, compound 4: 4.7-fold (0.68 log units) above, and the stated range ends above it.
By their numbers in this assay, from the lowest: compounds 4 and 3 (each within the scatter of the next); then compound 2.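

In this assay, the whole 3-(acetamidomethyl)-1,2-oxazol-5-yl group can be exchanged at this position, on the aromatic carbon next to the ring atom that bears an ethylcarbamoyl group, and the exchange for 1-isopropyl-1H-pyrazol-3-yl gives an 8.8-fold lower number from compound 2 to compound 4 (0.94 log units; beyond the scatter) and no loss. Among the compounds shown, the 1,2-oxazol-5-yl ring is therefore not required for a low number, and compound 4, whose entering group has no hydrogen-bond donor, lies within the scatter of compound 3, which keeps that ring and carries a diethylamino group. No measurement at hand accounts for the size of this step.

The compounds shown do not separate the contribution of the pyrazole ring from that of its isopropyl group. A 1H-pyrazol-3-yl ring carrying a longer chain or an amine in place of isopropyl would test that.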